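The source may report more compounds than this note shows. Statements on the series, on what has been measured and on what is new or still open speak of the compounds shown alone.

Working notes on the cyanoguanidine series. Two compounds have been run in an in vitro functional assay on Sf9 cells for antagonist activity at histamine H2 receptor (Homo sapiens); on this read-out higher numbers stand for higher potency (the scale is a negative logarithm) and lower numbers for lower potency. Compound 1 `N#C/N=C(/NCCCCc1c[nH]cn1)NCCCc1ccccn1` gives 5.48. For the measured compounds named here, compound 2 `N#C/N=C(/NCCCCc1c[nH]cn1)NCCCc1cccnc1` gives 5.92, the higher of the two numbers so far; its only neighbour is compound 1, and the one measured step, a number 0.44 log units higher from compound 1 to compound 2 (beyond the scatter), is modest but beyond the scatter. Both compounds share the same imidazolylbutyl cyanoguanidine core and differ only in which pyridinyl sits at the end of the three-carbon chain.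

Compound 3 `N#C/N=C(/NCCCCc1c[nH]cn1)NCCCc1ccncc1` is the third pyridinyl isomer: pyridin-4-yl in place of pyridin-3-yl on a saturated chain carbon, three bonds along the chain from an amine nitrogen. Going by the values given here, the only measured step that bears on it is a number 0.44 log units higher from compound 1 to compound 2 (beyond the scatter), which compares two other isomers of the same ring; nothing measured covers pyridin-4-yl itself, so that step sets the likely size of the change without fixing its direction. A shift of comparable size, up or down, is plausible, and no movement beyond the scatter is the central expectation. Compound 3 is therefore estimated at 5.9 in this assay, with a range from 5.3 to 6.5. The expected step, a number 0.02 log units lower from compound 2 to compound 3 (within the scatter), is thus essentially flat.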

Compound 3, negative logarithm of the antagonist equilibrium constant: 5.11
Beside the measured number, compound 3's estimate is 0.79 log units above it; measured number outside the range, below it.
By their numbers in this assay, from the lowest: compound 3; then compound 1; then compound 2.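

In this assay, the choice of isomer on a saturated chain carbon, three bonds along the chain from an amine nitrogen, is not neutral for pyridin-4-yl: a number 0.81 log units lower from compound 2 to compound 3 (beyond the scatter), and the same group also falls short of pyridin-2-yl, with a number 0.37 log units lower from compound 1 to compound 3 (beyond the scatter). All three steps among the isomers now lie beyond the scatter, so the series has a clear order: compound 2 with pyridin-3-yl is the most potent, compound 1 with pyridin-2-yl sits in the middle, and compound 3 with pyridin-4-yl is the least potent, an order that holds only for these three compounds on this one chain and core. Nothing available here accounts for this order or links it to any measured property of the rings.

As far as these compounds go, all three compounds carry the same chain, so it remains open whether pyridin-3-yl keeps its lead over pyridin-4-yl on a longer chain or a shorter chain. Also open, from the compounds shown here alone, is where a plain phenyl ring, or a pyridinyl ring carrying a methyl or an amine, would fall relative to these isomers.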